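The compounds below may be only part of what the source reports. "The series", "measured", "known", "first", "only" and "open" are said of these compounds alone.

Compound 1, `C#CCC(O)(c1ccc(N2CCN(S(=O)(=O)c3ccc(N)nc3)C[C@@H]2C#CC)cc1)C(F)(F)F`, is measured in an ADME assay (liver) for metabolic stability, with Liver microsome (Rattus norvegicus) as the target, using microsomes and NADPH, with a stated time of 30 min; a higher number here means faster removal of the compound, a lower number slower removal. In this assay, going by the values given here, compound 1 gives 59 mL.min-1.g-1, the only plain number among the values shown. Compound 2, `CC#C[C@H]1CN(S(=O)(=O)c2ccc(N)nc2)CCN1c1ccc(S(C)(=N)=O)cc1`, is the other measured compound. In this assay compound 2 gives < 14 mL.min-1.g-1, which is a limit of the assay rather than a number. Among the compounds with values here, the one measured step is an at least 4.2-fold lower number from compound 1 to compound 2 (0.62 log units; beyond the scatter); it rests on the limit of < 14 mL.min-1.g-1 in this assay, at which 1 of the 2 values shown sits, and swaps a far larger group than the change considered here. Compound 3, `CC#C[C@H]1CN(S(=O)(=O)c2ccc(N)nc2)CCN1c1ccc(C(O)(CC#N)C(F)(F)F)cc1`, differs from compound 1 by cyano in place of ethynyl on a saturated chain carbon, two bonds along the chain from an aromatic carbon and an oxygen on a saturated carbon. No measured step touches this change, since the only step shown swaps a different group on an aromatic carbon, so it gives no direction to lean on. With nothing pointing one way, the expectation for compound 3 is a step of about a 1.3-fold lower number from compound 1 to compound 3 (0.12 log units; within the scatter), inside the usual scatter of this assay. Compound 3 is therefore estimated to give 45 mL.min-1.g-1, with a range from 20 mL.min-1.g-1 to 100 mL.min-1.g-1.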

Compound 3, intrinsic clearance in microsomes: 57 mL.min-1.g-1
Estimate against measurement, compound 3: 1.3-fold (0.10 log units) below; measured number inside the range.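

In this assay, the change from propargyl to cyanomethyl gives a 1.0-fold lower number from compound 1 to compound 3 (0.01 log units; within the scatter), so at this saturated chain carbon a nitrile in place of the ethynyl end leaves compound 1 and compound 3 indistinguishable, even though the cyano group brings a hydrogen-bond acceptor that the ethynyl group lacks. The group on the aromatic carbon tells a different story, since the new comparison with the sulfur-containing group of compound 2 gives an at least 4.0-fold higher number from compound 2 to compound 3 (0.60 log units; beyond the scatter), which is the same kind of gap already seen with compound 1 and now holds with the nitrile in place. Compound 2 stands at a limit of the assay and not at a number, so that step gives only a minimum size: the limit of < 14 mL.min-1.g-1 in this assay, at which 1 of the 3 values shown sits.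

From the compounds shown here alone, it remains open whether other groups at the end of this chain, such as an amine, a carboxylic acid or a longer chain, would also leave the number unchanged. It is also unclear which part of the large group on the aromatic carbon goes with the higher numbers, and how large the gap to compound 2 really is.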